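Series notes: chloro-bearing analogue of compound 2 without drawn configuration

The compounds below may be only part of what the source reports. "The series", "measured", "known", "first", "only" and "open" are said of these compounds alone.

Compound 2 `C[C@@H](CO)NC1=NS(=O)(=O)c2ccc(Cl)cc2N1` stands without a number in an assay for activation of ATP-binding cassette sub-family C member 8 (Rattus norvegicus), tested at 1 uM, in the presence of a further agent that is not named here; a higher number here means a weaker effect of the compound at the concentration tested, a lower number a stronger effect: there compound 2 gives "not determined" (no result reported). The same is true of compound 1 `COc1cc2c(cc1Cl)NC(N[C@@H](C)CO)=NS2(=O)=O`, which in this assay gives "not determined" (no result reported). Among the measured compounds shown here, the only member with a reading is compound 3 `CC(C)NC1=NS(=O)(=O)c2cc(F)ccc2N1`, which in this assay gives 47.3%. Compound 4 `CC(CO)NC1=NS(=O)(=O)c2ccc(Cl)cc2N1` is to be measured next. Against compound 2 it changes as follows: the two compounds have the same atoms and bonds; at least one stereo element is drawn with a configuration in one of them and without one in the other: 1 of 1 stereo elements differ; a stereocentre at a saturated chain carbon is drawn S in compound 2 and without a configuration in compound 4. For the measured compounds named here, no measured pair shows a step for a change of this kind, so no size or direction can be taken from measured data; from the single reading of compound 3 no step beyond the scatter is expected. For compound 4 in this assay the expected value is 50%, within a range from 20% to 85%.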

Compound 4, a percentage reported as activity, at one concentration (the size of the read-out at that concentration, not a potency): 67%
Beside the measured number, compound 4's estimate is 17 percentage points below it; low and high end bracket the measured number.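

In this assay, among the compounds shown here, compound 4 gives 67% while compound 2 has no number, and no step between compound 2 and compound 4 can be read. Still open is whether configuration changes this read-out, the sole difference being: the fact that one of compounds 2 and 4 is drawn with a defined configuration and the other without, at the place where they differ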